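Swapping the ring at the edge of compound 1

The source may report more compounds than this note shows. Statements on the series, on what has been measured and on what is new or still open speak of the compounds shown alone.

Compound 1 `O=C(NCCCCc1ccccc1)n1c(=O)oc2cc(C3CCOCC3)ccc21` and compound 2 `O=C(NCCCCc1ccccc1)n1c2c(oc1=O)CCN(Cc1ccccc1)C2` share the same carbamoyl amide chain but differ in their core. For the measured compounds named here, in an assay on HEK293 cells for inhibition of acid ceramidase (Homo sapiens), read by fluorescence, with stated times of 10 min and 3 h (on this read-out lower numbers stand for stronger inhibition and higher numbers for weaker inhibition), compound 1 gives 68 nM, the lowest of the two numbers known so far. Compound 2 gives 436 nM in this assay, a gap that lies beyond the usual scatter, so compound 1 is the stronger of the two.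

Going by the values given here, compound 3 `CC(C)CN1CCC(c2ccc3c(c2)oc(=O)n3C(=O)NCCCCc2ccccc2)CC1` keeps the core of compound 1 and changes only one group: 1-isobutylpiperidin-4-yl in place of oxan-4-yl on an aromatic carbon. Among the compounds with values here, no measured pair shows this exact change, so the effect can only be expected, not read off. The ring that stays keeps the same size and the same count of hetero atoms, and the new basic nitrogen carries an isobutyl chain. The step from compound 1 to compound 3 is expected to be small, a 1.2-fold lower number from compound 1 to compound 3 (0.09 log units; within the scatter), and within the scatter. Compound 3 is therefore estimated at 55 nM in this assay, with a range from 14 nM to 220 nM.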

Compound 3, half-maximal inhibitory concentration: 120 nM
Estimate against measurement, compound 3: 2.2-fold (0.34 log units) below; measured number inside the range.
By their numbers in this assay, from the lowest: compounds 1 and 3 (each within the scatter of the next); then compound 2.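

In this assay, putting 1-isobutylpiperidin-4-yl in place of oxan-4-yl on this aromatic carbon gives a 1.8-fold higher number from compound 1 to compound 3 (0.25 log units; within the scatter), so this read-out cannot separate the two compounds. This is the first pair shown that differs in only one place, and it shows that this aromatic carbon accepts the larger group, with 10 heavy atoms in place of 6, and a ring nitrogen carrying an isobutyl chain in place of the ring oxygen, without a change beyond the scatter. Nothing measured here bears on the reason for this result.

Still open, from the compounds shown here alone, is what the isobutyl chain itself contributes, which piperidin-4-yl with only a hydrogen or a methyl group on its nitrogen would help to show. Also open, going by these compounds, is how a carboxylic acid or a primary amine on this same aromatic carbon would compare.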